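A Hydroxy on the Far Ring: Expected Effect on Growth Inhibition

The compounds below may be only part of what the source reports. "The series", "measured", "known", "first", "only" and "open" are said of these compounds alone.

The measured compounds, with their numbers in a functional assay on SF-295 cells (Homo sapiens) for cytotoxicity; on this read-out lower numbers stand for stronger inhibition of growth and higher numbers for weaker inhibition of growth:
Compound 1, `OCCC#Cc1ccccc1C#Cc1ccccc1`, gives 28100 nM.
Compound 2, `OCCCCC#Cc1ccccc1C#Cc1ccccc1`, gives 150 nM.
Compound 3, `OCCCCC#Cc1ccccc1C#Cc1ccccc1C(F)(F)F`, gives 2300 nM.

Compound 2 holds the lowest number of the three in this assay. Its nearest neighbour is compound 3, reached by the step of a 15-fold higher number from compound 2 to compound 3 (1.19 log units; beyond the scatter); the furthest is compound 1, from which the step of a 190-fold lower number from compound 1 to compound 2 (2.27 log units; beyond the scatter) leads to compound 2.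

Compound 4, `OCCCCC#Cc1ccccc1C#Cc1cccc(O)c1`, has not been measured. It differs from compound 2 by hydroxy in place of hydrogen on an aromatic carbon.

For the measured compounds named here, of the two measured steps, only the one from compound 2 to compound 3 touches the same ring, where a trifluoromethyl entering on an aromatic carbon raised the number by a 15-fold higher number from compound 2 to compound 3 (1.19 log units; beyond the scatter). The step from compound 1 to compound 2 concerns the chain and does not bear on this change. Going by the values given here, no measured pair shows a hydroxy entering on an aromatic carbon, so the one comparable step is a weak guide. The author expects a moderate rise in the number for compound 4, of about a 2.7-fold higher number from compound 2 to compound 4 (0.43 log units; beyond the scatter), and estimates that compound 4 will give 400 nM in this assay, within a range from 120 nM to 1500 nM.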

Compound 4, concentration for 50% growth inhibition: 21000 nM
Compound 4: the middle estimate sits 53-fold (1.72 log units) below what was measured, outside the stated range (above it).
By their numbers in this assay, from the lowest: compound 2; then compound 3; then compounds 4 and 1 (each within the scatter of the next).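

In this assay, a 140-fold higher number from compound 2 to compound 4 (2.15 log units; beyond the scatter) shows that the hydrogen on this aromatic carbon, meta to a large group, cannot be exchanged freely in compound 2, even for a group of 1 heavy atom. Until this result, the only change seen on this ring was a 15-fold higher number from compound 2 to compound 3 (1.19 log units; beyond the scatter), with trifluoromethyl entering; now two different groups have each raised the number well beyond the scatter, and no group shown on this ring keeps the low number of compound 2. Nothing given here accounts for the size of the rise from the hydroxy.

The compounds shown leave open whether this loss belongs to the hydroxy itself or to its place on the ring, as no compound here carries a hydroxy on any other carbon of that ring. On these data alone, it also remains open whether a methoxy, an amine or a carboxylic acid on the same carbon would give a number close to that of compound 2 or one as high as that of compound 4.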